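Removing the ethyl from compound 1: an expected small loss

This account rests on a few compounds, and the source may have more. Where it says the series, first, only, none or still open, it means among the compounds named here.

Of the compounds shown here, three have been measured in an assay on isolated protein for inhibition of proto-oncogene tyrosine-protein kinase receptor Ret variant V804M (Homo sapiens), read by radiometric assay and 33P incorporation, in the presence of a further agent that is not named here; on this read-out lower numbers stand for stronger inhibition and higher numbers for weaker inhibition. Compound 1 `CCc1cc(-c2nn(C(C)C)c3ncnc(N)c23)no1` gives 531 nM, the highest of the three numbers. Compound 2 `Nc1ncnc2c1c(-c1cc(C3CC3)on1)nn2C1CCOCC1` gives 41 nM, and compound 3 `CC(C)(O)Cn1nc(-c2cc(C3CC3)on2)c2c(N)ncnc21` gives 217 nM, so compound 1 stands well behind both. Among the compounds with values here, the one step between compounds that differ in a single place is a 5.3-fold higher number from compound 2 to compound 3 (0.72 log units; beyond the scatter), which concerns the group on the aromatic nitrogen and says nothing about the five-membered ring.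

Compound 4 `CC(C)n1nc(-c2ccon2)c2c(N)ncnc21` differs from compound 1 by hydrogen in place of ethyl on an aromatic carbon. Within the data shown here, no measured pair isolates this change: compounds 2 and 3 carry a cyclopropyl on that ring and also differ from compound 1 at the aromatic nitrogen. Without a matched step, only a cautious expectation is possible. Compound 4 is expected to give 900 nM, within 300 nM to 3000 nM. The expected step is a 1.7-fold higher number from compound 1 to compound 4 (0.23 log units; within the scatter), a slight rise in the number that may well fall within the scatter.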

Compound 4, half-maximal inhibitory concentration: 903 nM
Beside the measured number, compound 4's estimate is 1.0-fold (0.00 log units) below it; the measured number falls inside the stated range.
By their numbers in this assay, from the lowest: compound 2; then compound 3; then compounds 1 and 4 (each within the scatter of the next).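

In this assay, within the data shown here, this matched pair gives the first direct reading of the position on the aromatic carbon next to the ring oxygen, where hydrogen in place of ethyl comes with a 1.7-fold higher number from compound 1 to compound 4 (0.23 log units; within the scatter) and the two compounds cannot be told apart. With the rest of the core held fixed, the ethyl and its 2 carbons are therefore not shown to contribute measurably to this read-out, and the position tolerates the bare hydrogen. Nothing available here offers an explanation for this result.

As far as these compounds go, it remains open whether cyclopropyl at this position would separate from ethyl or hydrogen on the core of compound 1, as compound 2 and compound 3 also differ from it at the aromatic nitrogen. Also open, from the compounds shown here alone, is how a tert-butyl group or an amine would read on this carbon.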